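Swapping the sulfonyl arm for a ketone on the cyano olefin

The compounds below may be only part of what the source reports. "The series", "measured", "known", "first", "only" and "open" are said of these compounds alone.

Of the compounds shown here, two built on the same indole-derived core have been tested in a functional assay on NCI-H522 cells (Homo sapiens) for inhibition, read by sulforhodamine B assay, with a stated time of 48 h; on this read-out lower numbers stand for stronger inhibition of growth and higher numbers for weaker inhibition of growth. Compound 1 `O=C(/C(=C\c1c(-c2ccccc2)[nH]c2ccccc12)S(=O)(=O)c1ccccc1)c1ccccc1` carries a benzoyl and a phenylsulfonyl on its exocyclic double bond, and in this assay compound 1 gives 91800 nM. Compound 2 `N#C/C(=C\c1c(-c2ccccc2)[nH]c2ccccc12)S(=O)(=O)c1ccccc1` keeps the phenylsulfonyl but has a cyano instead of the benzoyl; in this assay compound 2 gives 4600 nM. Between them the only measured step, a 20-fold lower number from compound 1 to compound 2 (1.30 log units; beyond the scatter), is a large one, and compound 2 therefore stands as the lower of the two numbers.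

Compound 3 `N#C/C(=C\c1c(-c2ccccc2)[nH]c2ccccc12)C(=O)c1ccccc1` is the next candidate. Relative to compound 2 it changes a different position: benzoyl in place of phenylsulfonyl on a double-bonded chain carbon bound to a double-bonded chain carbon and a triple-bonded carbon. For the measured compounds named here, no measured step describes this sulfonyl-to-ketone exchange, so the one step seen, from compound 1 to compound 2, concerns another site and offers only a loose guide. The expected step in this assay, a 2.0-fold higher number from compound 2 to compound 3 (0.29 log units; within the scatter), is therefore a modest weakening. For compound 3 the estimated value in this assay is 9000 nM, with a range from 2500 nM to 35000 nM.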

Compound 3, concentration for 50% growth inhibition: 4000 nM
Beside the measured number, compound 3's estimate is 2.3-fold (0.35 log units) above it, and the stated range covers the measured number.
By their numbers in this assay, from the lowest: compounds 3 and 2 (each within the scatter of the next); then compound 1.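

In this assay, exchanging the phenylsulfonyl for a benzoyl gives a 1.2-fold lower number from compound 2 to compound 3 (0.06 log units; within the scatter), so with the cyano in place, the two groups cannot be told apart on this read-out. This also adds to what the earlier step, a 20-fold lower number from compound 1 to compound 2 (1.30 log units; beyond the scatter), could show: benzoyl alone does not go with a weak number, since compound 3 carries benzoyl and gives 4000 nM, whereas compound 1, with benzoyl and phenylsulfonyl together, gives 91800 nM. No supporting data are available to explain why the exchange makes so little difference here.

The compounds shown leave open whether this position would accept groups of a different kind, such as a carboxylic acid, an amide or a simple methyl, as readily as it accepts these two aromatic arms. On these data alone, it also remains open whether a group other than cyano, such as a methyl ester, could partner benzoyl or phenylsulfonyl on the same double bond and give a number close to those of compound 2 and compound 3.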